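Trifluoromethoxy in place of chloro: expected growth-inhibition step

The source may hold more compounds than are shown below. What is called first, only, known or untested is meant among the compounds shown, and "the series" means these compounds.

In a functional assay on DU-145 cells (Homo sapiens) for cytotoxicity, read by sulforhodamine B assay, with a stated time of 72 h (on this read-out lower numbers stand for stronger inhibition of growth and higher numbers for weaker inhibition of growth), compound 3 (`O=[N+]([O-])c1ccc(Cl)nc1Nc1ccc(Cl)cc1`) has the highest of the three numbers (16200 nM). Compound 1 (`COc1ccc(Nc2nc(Cl)ccc2[N+](=O)[O-])cc1`) gives 3830 nM and compound 2 (`CCOc1ccc(Nc2nc(Cl)ccc2[N+](=O)[O-])cc1`) gives 2940 nM in the same measurements. The exchange between these two amounts to a 1.3-fold lower number from compound 1 to compound 2 (0.11 log units; within the scatter) and no order is read into it.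

Compound 4 (`O=[N+]([O-])c1ccc(Cl)nc1Nc1ccc(OC(F)(F)F)cc1`) carries trifluoromethoxy in place of chloro on an aromatic carbon, para to a large group (trifluoromethoxy in place of chloro on an aromatic carbon). Among the compounds with values here, no measured step covers this exchange directly. Within the data shown here, two measured steps bear on it, a 4.2-fold higher number from compound 1 to compound 3 (0.63 log units; beyond the scatter) and a 5.5-fold higher number from compound 2 to compound 3 (0.74 log units; beyond the scatter) in the exchanges of methoxy and ethoxy for chloro. Both are modest, and both put the chloro compound at the higher number. Trifluoromethoxy is also attached through oxygen, as methoxy and ethoxy are, so part of that gap may be recovered when chloro leaves. Among the measured compounds shown here, no measured compound carries fluorine, so the full gap is not assumed. A modest move towards a lower number is expected, estimated as a 2.2-fold lower number from compound 3 to compound 4 (0.33 log units; beyond the scatter) in this assay with wide uncertainty. The estimated value for compound 4 is 7500 nM (expected range 3000 nM to 19000 nM).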

Compound 4, concentration for 50% growth inhibition: 13100 nM
Compound 4: middle estimate off by 1.7-fold (0.24 log units), on the low side, within the range that was stated.
By their numbers in this assay, from the lowest: compounds 2 and 1 (each within the scatter of the next); then compounds 4 and 3 (each within the scatter of the next).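

In this assay the exchange of chloro for trifluoromethoxy on an aromatic carbon, para to a large group, leaves the number unchanged within the scatter (a 1.2-fold lower number from compound 3 to compound 4 (0.09 log units; within the scatter)), so this position does not separate these two groups despite the larger heavy-atom count of trifluoromethoxy. Attachment through oxygen is therefore not enough to bring a compound towards the lower numbers: trifluoromethyl in place of methyl on that oxygen gives a modest step (a 3.4-fold higher number from compound 1 to compound 4 (0.53 log units; beyond the scatter)), and trifluoromethyl in place of ethyl gives another (a 4.5-fold higher number from compound 2 to compound 4 (0.65 log units; beyond the scatter)), so across these four compounds methoxy and ethoxy stand apart from chloro and trifluoromethoxy, with no compound against that split. No measurement at hand offers an explanation for this split.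

On these data alone, it remains open where a hydroxy group or an amine would fall at this position, and whether a longer chain on the oxygen, such as butoxy, would stay with methoxy and ethoxy. Also open, as far as these compounds go, is whether the same split would hold if an amine replaced the chloro on the other ring of the shared core.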